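The compounds below may be only part of what the source reports. "The series", "measured", "known", "first", "only" and "open" are said of these compounds alone.

Compound 1 `CC1(C)[C@@H]2CC[C@@]1(C)/C(=N/NC(=O)c1ccccc1)C2` is a hydrazone built on a bicyclic terpene-like core, carrying a benzoyl group on its amide-type nitrogen. It was tested in an ADME assay on MDCK cells (Canis lupus familiaris) for cytotoxicity, read by MTT assay, with a stated time of 48 h; a higher number here means that more compound is tolerated, a lower number that less compound is tolerated. In this assay compound 1 gives > 1040000 nM, which is a limit of the assay rather than a measured number. A second compound on the same core, compound 2 `CC12C=CC3(O1)C(C(=O)N1CCCOC13)C2C(=O)N/N=C1\C[C@H]2CC[C@]1(C)C2(C)C`, carries a much larger acyl group; in this assay compound 2 gives > 721000 nM, again a limit and not a number. Compound 3 `CC(=O)N/N=C1\C[C@H]2CC[C@]1(C)C2(C)C`, with a plain acetyl group on the same nitrogen, has in this assay the entry "not determined" (no result reported), so no result is available for it. Among the compounds with values here, compound 1 therefore stands at a limit of this assay, as does the one other compound with a reported value, since the limit of > 1040000 nM in this assay, at which 1 of the 3 values shown sits, and the limit of > 721000 nM in this assay, at which 1 of the 3 values shown sits, both mark only the top of the tested range.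

Compound 4 `CC1(C)[C@@H]2CC[C@@]1(C)/C(=N/NC(=O)c1ccco1)C2` differs from compound 1 in a single place (furan-2-yl in place of phenyl on a carbonyl carbon). Within the data shown here, no step between measured compounds is available, so any expectation rests on the two limits alone. The step from compound 1 to compound 4 is expected to be none beyond the scatter, as an at least 1.0-fold lower number from compound 1 to compound 4 (0.01 log units; that floor lies within the scatter). Compound 4 is therefore estimated at 1000000 nM, in the range from 300000 nM to 2000000 nM, most likely again reported as a limit.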

Compound 4, half-maximal cytotoxic concentration: 1090000 nM
Compound 4: middle estimate off by 1.1-fold (0.04 log units), on the low side, and the stated range covers the measured number.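

In this assay compound 1 gives > 1040000 nM, which is a limit and not a number. Compound 4 gives 1090000 nM. The step from compound 1 to compound 4 cannot be read. The compounds shown leave open whether furan-2-yl in place of phenyl on a carbonyl carbon changes how much compound the cells tolerate.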